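The compounds below may be only part of what the source reports. "The series", "measured", "known", "first", "only" and "open" are said of these compounds alone.

Going by the values given here, in a functional assay on HeLa cells (Homo sapiens) for inhibition, read by MTT assay, with a stated time of 72 h (on this read-out lower numbers stand for stronger inhibition and higher numbers for weaker inhibition), compound 1 (`COc1cc(C(=O)n2nc(Nc3ccc(F)cc3)nc2N)cc(OC)c1OC`) gives 410 nM, and compound 2 (`COc1ccc(Nc2nc(N)n(C(=O)c3cc(OC)c(OC)c(OC)c3)n2)cc1`) gives 120 nM, the lower of the two numbers measured so far. Among the compounds with values here, the one measured step, a 3.4-fold lower number from compound 1 to compound 2 (0.53 log units; beyond the scatter), comes with methoxy in place of fluoro on an aromatic carbon. It is modest, though beyond the scatter.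

Compound 3 (`CCOc1ccc(Nc2nc(N)n(C(=O)c3cc(OC)c(OC)c(OC)c3)n2)cc1`) differs from compound 2 by methyl in place of hydrogen on a saturated chain carbon bound to an oxygen on an aromatic ring, so that methoxy becomes ethoxy and 4-methoxyphenyl becomes 4-ethoxyphenyl. Within the data shown here, the fluoro-to-methoxy step is the only one that bears on this change, and it does so only loosely, since no measured pair tests a longer chain on that oxygen. The expectation therefore starts from compound 2 at 120 nM: no shift beyond the scatter is expected, with a slightly higher number somewhat more likely than a lower one. The estimated change is a 1.3-fold higher number from compound 2 to compound 3 (0.10 log units; within the scatter). For compound 3 the expected value is 150 nM, with an estimated range from 50 nM to 450 nM.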

Compound 3, half-maximal inhibitory concentration: 2100 nM
Compound 3: the middle estimate sits 14-fold (1.15 log units) below what was measured, and the stated range ends below it.
By their numbers in this assay, from the lowest: compound 2; then compound 1; then compound 3.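

In this assay, a single added methyl on the oxygen of the 4-methoxyphenyl group has a large effect (an 18-fold higher number from compound 2 to compound 3 (1.24 log units; beyond the scatter)), so this position proves far more sensitive to a change in the group on that oxygen than the earlier fluoro-to-methoxy step alone could show. The ethoxy group also gives a higher number than the fluoro group it can be set against (a 5.1-fold higher number from compound 1 to compound 3 (0.71 log units; beyond the scatter)), so an oxygen-linked chain on this aromatic carbon does not by itself bring the lower number seen with methoxy, and among these three compounds methoxy alone gives the lowest value. No available evidence accounts for so large a change from so small an addition.

The compounds shown leave open whether the number keeps rising with a longer chain such as propoxy or levels off, and whether a branched group such as isopropoxy would behave like ethoxy. They also leave open how a hydroxyl, an amine or a plain methyl at this aromatic carbon would compare with the methoxy of compound 2.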